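A Fluoro Group Added to the Benzyl of Compound 3

The compounds below may be only part of what the source reports. "The series", "measured", "known", "first", "only" and "open" are said of these compounds alone.

Within the data shown here, in a functional assay on A2780 cells (Homo sapiens) for cytotoxicity, read by MTT assay, with a stated time of 48 h (on this read-out higher numbers stand for weaker inhibition and lower numbers for stronger inhibition), three compounds have numbers so far. Compound 1 `COc1ccc(CNC(=O)CC2c3ccccc3N=C(N(C)CCCCCN(C)C)N2c2ccc(-c3ccccc3)cc2)cc1` gives 1380 nM, compound 2 `CN(C)CCCCCCN(C)C1=Nc2ccccc2C(CC(=O)NCc2ccccc2)N1c1ccc(-c2ccccc2)cc1` gives 1190 nM, and compound 3 `CN(C)CCN1CCN(C2=Nc3ccccc3C(CC(=O)NCc3ccccc3)N2c2ccc(-c3ccccc3)cc2)CC1` gives 1390 nM. These numbers lie within the usual scatter of one another, so compound 3 stands level with the other two and none can be ranked.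

Compound 4 `CN(C)CCN1CCN(C2=Nc3ccccc3C(CC(=O)NCc3ccc(F)cc3)N2c2ccc(-c3ccccc3)cc2)CC1` differs from compound 3 in one place: fluoro in place of hydrogen on an aromatic carbon. Here fluoro replaces hydrogen on an aromatic carbon, which turns benzyl into 4-fluorobenzyl.

Among the measured compounds shown here, only one measured step joins two compounds that differ in one place: a 1.2-fold higher number from compound 2 to compound 3 (0.07 log units; within the scatter). It exchanges the amine chain rather than touching the benzyl, and it stays within the scatter, so it bears on the new change only indirectly. Compound 1, which has an added group on its benzyl ring as well as a different chain, sits in the same range at 1380 nM. For the measured compounds named here, no measured step shows the fluoro change itself, so no step beyond the scatter is expected, and direction cannot be called. The estimated change in this assay is a 1.1-fold lower number from compound 3 to compound 4 (0.05 log units; within the scatter).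

For compound 4 the expected value is 1250 nM, with an estimated range from 650 nM to 2300 nM.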

Compound 4, half-maximal inhibitory concentration: 1600 nM
Beside the measured number, compound 4's estimate is 1.3-fold (0.11 log units) below it, and the stated range covers the measured number.
By their numbers in this assay, from the lowest: compounds 2, 1, 3 and 4 (each within the scatter of the next).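

In this assay, fluoro in place of hydrogen on the benzyl ring of compound 3, at the aromatic carbon para to a large group, gives a 1.2-fold higher number from compound 3 to compound 4 (0.06 log units; within the scatter). Among these compounds, this is the first measured step that touches this ring on its own, since the earlier step exchanged the amine chain and compound 1 differs from the others in both its benzyl ring and its chain. It shows that swapping this hydrogen for a single fluorine leaves the cytotoxicity number within the usual scatter, so the change has no readable effect in either direction, and no measurement shown here offers an explanation for that result.

From the compounds shown here alone, one small atom at one place says little about the wider reach of this ring, so it remains open whether a bulkier group such as trifluoromethyl, or a carboxylic acid or an amine, would move the number beyond the scatter at this carbon. Also open, going by these compounds, is whether fluoro on another carbon of the same ring, or on the benzyl ring of a compound with a different amine chain, would read the same way.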